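This account rests on a few compounds, and the source may have more. Where it says the series, first, only, none or still open, it means among the compounds named here.

Compound 1 `O=C(Nc1nnc(-c2ccccc2)s1)c1cc(Cl)ccc1O` and compound 2 `O=C(Nc1nnc(-c2ccc(Cl)cc2)s1)c1cc(Cl)ccc1O` share one core, and in a functional assay on MCF7 cells (Homo sapiens) for antiproliferative activity, read by MTT assay, with a stated time of 48 h (on this read-out higher numbers stand for weaker inhibition and lower numbers for stronger inhibition), compound 1 gives 1120 nM while compound 2 gives 450 nM. The change between them, (chloro in place of hydrogen on an aromatic carbon), produced a 2.5-fold lower number from compound 1 to compound 2 (0.40 log units; beyond the scatter). Compound 3 `O=C(Nc1nnc(-c2ccccc2)s1)c1ccccc1` stands on a different core; the difference between the two cores is not broken down here. In this assay compound 3 gives 5870 nM, the highest of the three numbers. Compound 4 `O=C(Nc1nnc(-c2ccccc2)s1)c1ccc(Cl)cc1` is not yet measured and differs from compound 3 by chloro in place of hydrogen on an aromatic carbon, the same change as from compound 1 to compound 2. Because a 2.5-fold lower number from compound 1 to compound 2 (0.40 log units; beyond the scatter) was modest, a step of similar size, a 2.0-fold lower number from compound 3 to compound 4 (0.31 log units; beyond the scatter), is expected in this assay on this core as well. Compound 4 is therefore estimated at 2900 nM, likely between 1200 nM and 6500 nM.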

Compound 4, half-maximal inhibitory concentration: 4490 nM
Compound 4: middle estimate off by 1.5-fold (0.19 log units), on the low side, and the stated range covers the measured number.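

In this assay, chloro in place of hydrogen gave a 1.3-fold lower number from compound 3 to compound 4 (0.12 log units; within the scatter) and so, on the core of compound 3, the change cannot be told apart from repeat measurement. Set beside the earlier step, the two steps do not differ by more than the scatter allows: the same change on two cores in this assay, a 2.5-fold lower number (0.40 log units; beyond the scatter) from compound 1 to compound 2 and a 1.3-fold lower number (0.12 log units; within the scatter) from compound 3 to compound 4, 1.9-fold (0.28 log units) apart, within the scatter of two such steps. This shows that the result on the core of compound 3 is compatible with the step on the core of compound 1, but it does not show that the change has the same size on both cores or that it would carry to any further core.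

The compounds shown leave open how other groups in the place of chloro, such as a methoxy group or an amine, would read in this assay. They also leave open whether the change would give a step beyond the scatter on other cores.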